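The source may hold more compounds than are shown below. What is called first, only, known or untested is meant among the compounds shown, and "the series" means these compounds.

Measured compounds:
compound 1, `Cc1c(OCCCCOc2ccc(Cl)c(C(=O)O)c2)ccc(C(=O)CC(C)(C)C)c1O`, 87 nM
compound 2, `COc1ccc(C(=O)O)cc1OC[C@@H](C)Oc1ccc(C(=O)CC(C)(C)C)c(O)c1C`, 78 nM
compound 3, `Cc1c(OC[C@@H](C)COc2ccc(C(=O)O)cc2F)ccc(C(=O)CC(C)(C)C)c1O`, 222 nM

In an assay for positive allosteric modulation of metabotropic glutamate receptor 2 (Rattus norvegicus) (on this read-out higher numbers stand for an effect only at larger amounts of compound and lower numbers for an effect already at smaller amounts), compound 3 stands at the highest number of the three measured compounds. Compound 1 and compound 2 both sit at lower numbers, and both gaps to compound 3 exceed the usual scatter of this assay. Compound 4, `COc1cccc(OC[C@H](C)COc2ccc(C(=O)CC(C)(C)C)c(O)c2C)c1`, has not yet been measured in this assay. It differs from compound 3 in one place: 3-methoxyphenyl in place of 4-carboxy-2-fluorophenyl on an oxygen on a saturated carbon. For the measured compounds named here, every measured compound carries a carboxy group on its outer aromatic ring, and compound 4 is the first without one; no pair of measured compounds shows what removing it does, so the expectation rests on little. Compound 3 already gives 222 nM in this assay, the weakest point of the set. The step of a 2.7-fold higher number from compound 3 to compound 4 (0.43 log units; beyond the scatter) is expected to run toward a larger number, beyond the scatter but not by a wide margin. Compound 4 is thus estimated at 600 nM, within a range from 150 nM to 2500 nM.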

Compound 4, half-maximal effective concentration: "not active" (no number reported)
No number was reported for compound 4; the estimate stays without a comparison.
By their numbers in this assay, from the lowest: compounds 2 and 1 (each within the scatter of the next); then compound 3.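

For the compounds shown here, compound 4 is reported as not active, with no number, so no step from compound 3 to compound 4 can be read. No measured property bears on this result. The compounds shown leave open whether 3-methoxyphenyl in place of a carboxy-bearing ring would give the same outcome on the chains of compound 1 or compound 2.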